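The source may report more compounds than this note shows. Statements on the series, on what has been measured and on what is new or still open speak of the compounds shown alone.

Measured values: in a functional assay on HEK293 cells for agonist activity at probable G-protein coupled receptor 27 (Homo sapiens), read by a luciferase reporter and beta-arrestin recruitment, with a stated time of 10 min (a higher number here means a larger maximal response, a lower number a smaller maximal response), compound 1, `Cc1cc(Cl)ccc1C(=O)Nc1ccc(S(=O)(=O)Nc2ccccc2)cc1`, gives 123%. In this assay compound 2, `N#Cc1ccc(C(=O)Nc2ccc(S(=O)(=O)Nc3ccccc3)cc2)c(F)c1`, gives 29%. In this assay compound 3, `O=C(Nc1ccc(S(=O)(=O)Nc2ncccn2)cc1)c1ccc(Cl)cc1Cl`, shows "not determined" (no result reported), so no number is reported for it.

Among the two numbers shown, compound 2 stands lowest in this assay: compound 1 lies far above it, and compound 3 contributes no number to compare. Among the measured compounds shown here, the one measured step that speaks to this series is a number 94 percentage points lower from compound 1 to compound 2 (beyond the scatter); it came with the change from 4-chloro-2-methylphenyl to 4-cyano-2-fluorophenyl on the carbonyl carbon, so two things moved at once, and nothing separates their shares.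

Compound 4, `O=C(Nc1ccc(S(=O)(=O)Nc2ccccc2)cc1)c1ccc(Cl)cc1F`, is to be measured in this assay. Its difference from compound 2 is chloro in place of cyano on an aromatic carbon. Compound 4 therefore keeps the fluoro group of compound 2 but carries the chloro group seen in compound 1. For the measured compounds named here, because the one measured step is a number 94 percentage points lower from compound 1 to compound 2 (beyond the scatter), returning the chloro group is expected to recover part of that loss, while the fluoro group that remains leaves the size uncertain. The expected step is a number 56 percentage points higher from compound 2 to compound 4 (beyond the scatter), upward and beyond the scatter. Compound 4 is estimated at 85%, within 40% to 125%.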

Compound 4, largest response reached (Emax), in percent of the reference or control that the assay uses: 57%
The estimate for compound 4 lay 28 percentage points above the measured number; low and high end bracket the measured number.
By their numbers in this assay, from the lowest: compound 2; then compound 4; then compound 1.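

Among the compounds shown here, the single step from compound 1 to compound 2 changed two groups at once, and compound 4 now lets the two changes be read separately. At the position para to a large group, with the fluoro group held in place, chloro in place of cyano gives a number 28 percentage points higher from compound 2 to compound 4 (beyond the scatter) in this assay, so the nitrile-bearing compound 2 responds less than its chloro partner, though this is the modest part of the earlier fall. With the chloro group held in place, fluoro in place of methyl on an aromatic carbon gives a number 66 percentage points lower from compound 1 to compound 4 (beyond the scatter), the large part, which shows that the maximal response depends on both places and on the methyl-to-fluoro change most of all.

These two steps each hold a different partner group fixed, so the compounds shown do not tell whether the methyl-to-fluoro step would be the same size with a nitrile present, nor how a methoxy group or an amine in place of chloro would compare. The reason for either step also remains open, as no measurement here bears on it.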